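Pyridin-2-yl in place of chlorophenyl on the acrylamide chain

This account rests on a few compounds, and the source may have more. Where it says the series, first, only, none or still open, it means among the compounds named here.

Of the compounds shown here, three sharing one core have been measured in a functional assay on MDA-MB-231 cells (Homo sapiens) for inhibition, read by MTT assay, with a stated time of 48 h; a higher number here means a weaker inhibitor, a lower number a stronger inhibitor. Compound 1 `COc1cc(/C=C/c2ccc(NC(=O)/C=C/c3ccc(OC)c(OC)c3)cc2)cc(OC)c1` gives 7740 nM, compound 2 `COc1cc(/C=C/c2ccc(NC(=O)/C=C/c3ccc(C(F)(F)F)cc3)cc2)cc(OC)c1` gives 3520 nM, and compound 3 `COc1cc(/C=C/c2ccc(NC(=O)/C=C/c3ccc(Cl)cc3)cc2)cc(OC)c1` gives 14100 nM, the highest of the three numbers. The step of a 1.8-fold higher number from compound 1 to compound 3 (0.26 log units; within the scatter) lies within the scatter, while the step of a 4.0-fold higher number from compound 2 to compound 3 (0.60 log units; beyond the scatter) and the step of a 2.2-fold lower number from compound 1 to compound 2 (0.34 log units; beyond the scatter) lie beyond it.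

Compound 4 `COc1cc(/C=C/c2ccc(NC(=O)/C=C/c3ccccn3)cc2)cc(OC)c1` differs from compound 3 by pyridin-2-yl in place of 4-chlorophenyl on a double-bonded chain carbon bound to a double-bonded chain carbon. Among the compounds with values here, the measured steps that touch the same place are the aryl swaps from compound 1 and from compound 2 to compound 3, which were small to modest; none of them brings in a ring with a hetero atom, so the new group has no direct precedent here. On that basis a step of at most modest size is expected, with no clear direction, as a 1.4-fold lower number from compound 3 to compound 4 (0.15 log units; within the scatter). For compound 4 the estimated value in this assay is 10000 nM, within a range from 3000 nM to 40000 nM.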

Compound 4, half-maximal inhibitory concentration: 3400 nM
Estimate against measurement, compound 4: 2.9-fold (0.47 log units) above, within the range that was stated.
By their numbers in this assay, from the lowest: compounds 4 and 2 (each within the scatter of the next); then compounds 1 and 3 (each within the scatter of the next).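

At this place, on a double-bonded chain carbon bound to a double-bonded chain carbon, a ring with a hetero atom holds up in this assay: pyridin-2-yl in place of 4-chlorophenyl gives a 4.1-fold lower number from compound 3 to compound 4 (0.62 log units; beyond the scatter), so the ring here need not be carbon only. The same swap gives a 2.3-fold lower number from compound 1 to compound 4 (0.36 log units; beyond the scatter) against 3,4-dimethoxyphenyl, while a 1.0-fold lower number from compound 2 to compound 4 (0.02 log units; within the scatter) leaves pyridin-2-yl and 4-(trifluoromethyl)phenyl indistinguishable, so two quite different rings reach the same level here.

From the compounds shown here alone, what pyridin-3-yl or pyridin-4-yl would give at this place remains open, and so does whether the ring nitrogen matters at all, which plain phenyl would help to settle. A pyrimidinyl or thiazolyl ring could also show how far this result extends. No measurement shown explains any of these steps.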